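The source may report more compounds than this note shows. Statements on the series, on what has been measured and on what is new or still open speak of the compounds shown alone.

Of the compounds shown here, three from this series have been measured in a functional assay on Jurkat cells (Homo sapiens) for cytotoxicity, read by MTT assay, with a stated time of 72 h; a lower number here means a stronger inhibitor, a higher number a weaker inhibitor. Compound 1 `COC(=O)c1sc2cc(OC)ccc2c1Nc1cc(OC)c(OC)c(OC)c1` gives 1.7 nM. Compound 2 `COC(=O)c1sc2cc(C)ccc2c1Nc1cc(OC)c(OC)c(OC)c1` gives 0.6 nM in this assay. Compound 3 `CCOC(=O)c1sc2cc(C)ccc2c1Nc1cc(OC)c(OC)c(OC)c1` gives 0.4 nM in this assay. Compound 2 and compound 3 share a core that differs by methyl in place of hydrogen on a saturated chain carbon bound to an oxygen next to a carbonyl group, and the step of a 1.5-fold lower number from compound 2 to compound 3 (0.18 log units; within the scatter) lies within the usual scatter, so the two values cannot be told apart.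

For the measured compounds named here, from compound 2 to compound 1 the change is methoxy in place of methyl on an aromatic carbon, and it produced the step of a 2.8-fold higher number from compound 2 to compound 1 (0.45 log units; beyond the scatter), the only step here that reaches beyond the scatter. Compound 1 also stands furthest from compound 3, as their two values show.

Compound 4 `CCOC(=O)c1sc2cc(OC)ccc2c1Nc1cc(OC)c(OC)c(OC)c1` has not yet been measured in this assay. It differs from compound 3 by methoxy in place of methyl on an aromatic carbon. This is the same change that separates compound 2 from compound 1, made at the same place, but on the core of compound 3 rather than that of compound 2; the two cores differ only in ethoxycarbonyl against methoxycarbonyl, as already told. For compound 4 a step of a 2.8-fold higher number from compound 3 to compound 4 (0.44 log units; beyond the scatter) is expected in this assay. That expectation rests on the step of a 2.8-fold higher number from compound 2 to compound 1 (0.45 log units; beyond the scatter), which the same change made on the core of compound 2, with no sign from compound 2 and compound 3 that the core alters the outcome. Compound 4 is therefore estimated at 1.1 nM, within a range from 0.5 nM to 2.5 nM.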

Compound 4, half-maximal inhibitory concentration: 3.3 nM
Beside the measured number, compound 4's estimate is 3.0-fold (0.48 log units) below it; measured number outside the range, above it.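

In this assay, methoxy in place of methyl on an aromatic carbon gives an 8.3-fold higher number from compound 3 to compound 4 (0.92 log units; beyond the scatter) on the ethoxycarbonyl core, so the change raises the number on both cores, but its size does not carry over from the methoxycarbonyl core: the same change on two cores in this assay, a 2.8-fold higher number (0.45 log units; beyond the scatter) from compound 2 to compound 1 and an 8.3-fold higher number (0.92 log units; beyond the scatter) from compound 3 to compound 4, 2.9-fold (0.46 log units) apart, beyond the scatter of two such steps.

Read the other way, methyl in place of hydrogen on a saturated chain carbon bound to an oxygen next to a carbonyl group gives a 1.9-fold higher number from compound 1 to compound 4 (0.29 log units; within the scatter) and leaves compound 1 and compound 4 indistinguishable, as compound 2 and compound 3 are, yet the two steps still do not match: the same change on two cores in this assay, a 1.5-fold lower number (0.18 log units; within the scatter) from compound 2 to compound 3 and a 1.9-fold higher number (0.29 log units; within the scatter) from compound 1 to compound 4, 2.9-fold (0.46 log units) apart, beyond the scatter of two such steps.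

Both comparisons rest on the same four compounds and so describe a single gap seen from two sides; it shows that the direction of the methoxy change held on these two cores and that its size depended on the core, but it does not explain the gap or show how the change would behave on any further core.

The compounds shown leave open whether the same dependence on the core would appear with a hydrogen, a chlorine or an ethoxy group at that aromatic carbon. They also leave open what a longer chain on the ester, or a carboxylic acid or an amide in its place, would do to the step.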